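Rearranging the carbamate chain of compound 1

The source may report more compounds than this note shows. Statements on the series, on what has been measured and on what is new or still open speak of the compounds shown alone.

Compound 1 `CC1=C(N2CC2)C(=O)C(CCCOC(N)=O)=C(N2CC2)C1=O` stands highest of the two numbers measured in a functional assay on L1210 cells (Mus musculus), with a stated time of 1 days; on this read-out higher numbers stand for higher potency (the scale is a negative logarithm) and lower numbers for lower potency; compound 1 gives 5.48. Its nearest neighbour is compound 2 `CC1=C(N2CC2)C(=O)C(CCCc2ccccc2)=C(N2CC2)C1=O`, which in this assay gives 3.6; the step of a number 1.88 log units lower from compound 1 to compound 2 (beyond the scatter) is large and beyond the scatter. Compound 3 `CC1=C(N2CC2)C(=O)C(C(C)COC(N)=O)=C(N2CC2)C1=O` has not yet been measured. It differs from compound 1 by a group of 7 heavy atoms (4 carbon, 1 nitrogen, 2 oxygen; no ring) in place of a group of 7 heavy atoms (4 carbon, 1 nitrogen, 2 oxygen; no ring), on a double-bonded ring carbon: the two have the same atoms, joined differently, and the carbamate is kept. Among the compounds with values here, the only measured step replaces the carbamoyloxy group with phenyl and so speaks to loss of the carbamate rather than to this rearrangement. Because the large drop a number 1.88 log units lower from compound 1 to compound 2 (beyond the scatter) followed removal of the carbamoyloxy group, which compound 3 retains, the expected step of a number 0.18 log units lower from compound 1 to compound 3 (within the scatter) is small, at most a modest loss. Compound 3 is therefore estimated at 5.3, with a range from 4.7 to 5.9.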

Compound 3, logarithm of the reciprocal of the active concentration, log(1/C): 5.31
For compound 3 the middle estimate is 0.01 log units below the measured one; the range from low to high includes it.
By their numbers in this assay, from the lowest: compound 2; then compounds 3 and 1 (each within the scatter of the next).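

Rejoining the same atoms on the double-bonded ring carbon, with the carbamate kept, gives a number 0.17 log units lower from compound 1 to compound 3 (within the scatter) in this assay. Within the data shown here, the only earlier step, a number 1.88 log units lower from compound 1 to compound 2 (beyond the scatter), replaced the carbamoyloxy group with phenyl, so it could not show how much the way the chain is joined matters. This pair isolates that question: at this position, in this assay, the two arrangements of the group of 7 heavy atoms cannot be told apart. Nothing measured here gives a cause for this result.

The compounds shown leave open whether a longer chain carrying the carbamate would hold the value of compound 1. They also leave open whether a hydroxyl or an amine in place of the carbamoyloxy group would do so, or would fall as the phenyl compound does.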